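Swapping a Two-Ring Arm for Pyridin-2-yl: Solubility Outlook

A few compounds are considered here, and "the series" means these few. Any claim that something is new, unique, unknown or untested is made for them only; others in the source may bear on it.

Measured so far:
compound 1 `CC1SC(c2cccc(C(=O)NCCCCc3ccccc3)c2)N(c2ccc(C3CC3)cc2)C1=O` gives 10000 nM
compound 2 `O=C(NCCCCc1ccccc1)c1cccc(C2SCC(=O)N2c2cccc(-c3c[nH]nn3)c2)c1` gives 20000 nM
compound 3 `COc1ccc(F)cc1N1C(=O)CSC1c1cccc(C(=O)NCCCCn2cccn2)c1` gives 50000 nM

These three compounds share a core and were all tested in a physicochemical assay for solubility, read by turbidimetry, measured as kinetic solubility, at pH 6.8; a lower number here means a less soluble compound, a higher number a more soluble compound. Compound 2 holds the second highest of the three numbers; its gap to compound 1 lies within the usual scatter, while compound 3 sits beyond it with the higher number. Compound 4 `O=C(NCCCCc1ccccc1)c1cccc(C2SCC(=O)N2c2ccccn2)c1` has not been measured yet. It differs from compound 2 in one place: a group of 6 heavy atoms (5 carbon, 1 nitrogen; one six-membered aromatic ring with 1 hetero atom) in place of a group of 11 heavy atoms (8 carbon, 3 nitrogen; one five-membered aromatic ring with 3 hetero atoms, one six-membered aromatic ring of carbon only), on an amide-type nitrogen in a ring. For the measured compounds named here, no two measured compounds differ in a single place, so no step size is known from the data. For compound 4 the step from compound 2 is expected to be modest and toward a higher number, barely past the scatter: a 1.5-fold higher number from compound 2 to compound 4 (0.18 log units; within the scatter). Compound 4 is therefore estimated at 30000 nM, with a range from 10000 nM to 90000 nM.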

Compound 4, solubility: 20000 nM
Beside the measured number, compound 4's estimate is 1.5-fold (0.18 log units) above it; measured number inside the range.
By their numbers in this assay, from the lowest: compounds 1, 2 and 4 (each within the scatter of the next); then compound 3.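

In this assay, for the compounds shown here, this pair gives the first readable step on the amide-type nitrogen in the ring, no change at the digits printed from compound 2 to compound 4 (within the scatter), with the rest of the molecule held constant. Pyridin-2-yl, a single six-membered aromatic ring with 0 hydrogen-bond donors, therefore cannot be told apart in this read-out from the larger two-ring arm with 1 hydrogen-bond donor. Nothing on hand explains this result.

From the compounds shown here alone, whether a group carrying an amine or a carboxylic acid at this nitrogen would give a step beyond the scatter remains open. A single pair also cannot show whether other changes at this position would behave the same way.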